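Triazole substituent changes on a shared lactone core

The source may report more compounds than this note shows. Statements on the series, on what has been measured and on what is new or still open speak of the compounds shown alone.

Measured so far in a functional assay on SW-620 cells (Homo sapiens) for antiproliferative activity, read by MTT assay, with a stated time of 72 h; on this read-out lower numbers stand for stronger inhibition and higher numbers for weaker inhibition:
compound 1 `C[Si](C)(C)c1cn(C[C@H](O)[C@H]2OC(=O)C(OCc3ccccc3)=C2OCc2ccccc2)nn1` gives 56000 nM.
compound 2 `Cc1ccc(-c2cn(C[C@H](O)[C@H]3OC(=O)C(OCc4ccccc4)=C3OCc3ccccc3)nn2)cc1` gives only a limit of the assay, > 100000 nM.
compound 3 `O=C1O[C@H]([C@@H](O)Cn2cc(C3CC3)nn2)C(OCc2ccccc2)=C1OCc1ccccc1` gives 54200 nM.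

Compound 3 holds the lowest of the two numbers, with compound 1 nearest; their gap, a 1.0-fold lower number from compound 1 to compound 3 (0.01 log units; within the scatter), sits within the scatter. Compound 4 `CCCCCCCCCCc1cn(C[C@H](O)[C@H]2OC(=O)C(OCc3ccccc3)=C2OCc2ccccc2)nn1` differs from compound 3 in one place: decyl in place of cyclopropyl on an aromatic carbon. Among the measured compounds shown here, two measured steps touch the same aromatic carbon. The step of an at least 1.8-fold lower number from compound 2 to compound 3 (0.26 log units; that floor lies within the scatter) begins at a limit. The step of a 1.0-fold lower number from compound 1 to compound 3 (0.01 log units; within the scatter) is flat. Neither change at that carbon moved this assay beyond the scatter, so no step beyond the scatter is expected for decyl either, although a chain of this length has no precedent among these compounds. Compound 4 is expected at 50000 nM, range 15000 nM to 150000 nM, meaning a step of a 1.1-fold lower number from compound 3 to compound 4 (0.04 log units; within the scatter).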

Compound 4, half-maximal inhibitory concentration: 45200 nM
Estimate against measurement, compound 4: 1.1-fold (0.04 log units) above; the measured number falls inside the stated range.
By their numbers in this assay, from the lowest: compounds 4, 3 and 1 (each within the scatter of the next). At a limit, above all of these: compound 2.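

In this assay, decyl at this aromatic carbon sits level with cyclopropyl, a 1.2-fold lower number from compound 3 to compound 4 (0.08 log units; within the scatter), and with the silicon-bearing group of compound 1, a 1.2-fold lower number from compound 1 to compound 4 (0.09 log units; within the scatter), so a long ringless chain changes nothing beyond the scatter. Among the compounds shown here, the one step beyond the scatter, an at least 2.2-fold lower number from compound 2 to compound 4 (0.34 log units; beyond the scatter), starts from compound 2, whose value is a limit and not a number: the limit of > 100000 nM in this assay, at which 1 of the 4 values shown sits. Decyl has more heavy atoms than 4-methylphenyl yet stays off that limit, so group size alone does not separate compound 2 from compounds 1, 3 and 4.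

Open, as far as these compounds go, is whether an amine or a carboxylic acid at the end of the chain, or a longer chain, would move the number beyond the scatter. Also open, from the compounds shown here alone, is whether a second aromatic group at this carbon would stay at the limit like compound 2.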